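The compounds below may be only part of what the source reports. "The series", "measured", "known", "first", "only" and "open" are said of these compounds alone.

Two measured compounds set the frame. Compound 1, `Cn1ccnc1C#Cc1cc(Cl)ccc1OCC(=O)O`, gives 1470 nM in an assay on CHO cells for displacement of a labelled ligand from prostaglandin D2 receptor 2 (Homo sapiens), read by scintillation counting; a lower number here means a stronger inhibitor, a higher number a weaker inhibitor. Compound 2, `CS(=O)(=O)c1cncc(C#Cc2cc(Cl)ccc2OCC(=O)O)c1`, gives 60 nM in this assay, the lower of the two numbers, and the gap between compound 2 and compound 1 lies beyond the usual scatter of repeated measurements. Compound 3, `O=C(O)COc1ccc(Cl)cc1C#Cc1cccnc1`, has not yet been measured in this assay. It differs from compound 2 in one place: hydrogen in place of methylsulfonyl on an aromatic carbon. For the measured compounds named here, no measured pair in this set shows what removing this group does on its own, so the expectation rests on compound 2 alone and on the size of the change, which strips away the only substituent on that ring. Compound 3 is expected to sit weaker than compound 2, with an estimated 400 nM in this assay and a likely range from 120 nM to 1500 nM. The step of a 6.7-fold higher number from compound 2 to compound 3 (0.82 log units; beyond the scatter) is thus expected to be a loss of potency beyond the scatter, though smaller than the gap that separates compound 1 from compound 2. Whether the measurement lands nearer the one or the other is what remains to be seen.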

Compound 3, inhibition constant: 117 nM
For compound 3 the middle estimate is 3.4-fold (0.53 log units) above the measured one; measured number outside the range, below it.
By their numbers in this assay, from the lowest: compounds 2 and 3 (each within the scatter of the next); then compound 1.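

In this assay, hydrogen in place of methylsulfonyl on an aromatic carbon gives a 2.0-fold higher number from compound 2 to compound 3 (0.29 log units; within the scatter), so at this place, two atoms from the ring nitrogen, the number holds within the scatter without the methylsulfonyl group. The other step, pyridin-3-yl in place of 1-methyl-1H-imidazol-2-yl on a triple-bonded carbon, gives a 13-fold lower number from compound 1 to compound 3 (1.10 log units; beyond the scatter), which shows that a pyridin-3-yl ring with no added substituent is enough for a large difference from compound 1, and that here the choice of ring counts for more than the methylsulfonyl group on it. No supporting measurement is at hand to say why either step turns out as it does.

Only hydrogen and methylsulfonyl are shown at this place, so the compounds leave open whether a methoxy group, an amine or a carboxylic acid there would part from compound 2 and compound 3 by more than the scatter. Also open, on these data alone, is how a plain phenyl ring or a pyridin-4-yl ring on the triple-bonded carbon would compare with the pyridin-3-yl ring of compound 3.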